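The source may report more compounds than this note shows. Statements on the series, on what has been measured and on what is new or still open speak of the compounds shown alone.

Measured compounds:
Compound 1 `CNC(=O)c1cc(C(=O)NC2CC2)cn(Cc2ccc(OC)cc2)c1=O` gives 3 in a physicochemical assay for lipophilicity, at pH 7.4; a lower number here means a more polar compound, a higher number a more lipophilic compound.
Compound 2 `CNC(=O)c1cc(C(=O)NC2CCC2)cn(Cc2cccc(NC)c2)c1=O` gives 3.6 in this assay.

On these two numbers compound 1 stands lowest, with compound 2 the nearest, and the gap between them lies beyond the scatter. Within the data shown here, no step between measured compounds of a single change is available here.

Compound 3 `CNC(=O)c1cc(C(=O)NC2CC2)cn(Cc2cccc3cc[nH]c23)c1=O` differs from compound 1 by 1H-indol-7-yl in place of 4-methoxyphenyl on a saturated chain carbon bound to an aromatic nitrogen. Among the measured compounds shown here, for this change no measured step exists, and the chemists expect the step in this assay to be small, most likely none beyond the scatter or a slight rise. Compound 3 is therefore estimated at 3.1, within 2.7 to 3.5. The expected step from compound 1 is a number 0.10 log units higher from compound 1 to compound 3 (within the scatter).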

Compound 3, distribution coefficient: 3.7
Compound 3: middle estimate off by 0.60 log units, on the low side; the measured number lies above the stated range.
By their numbers in this assay, from the lowest: compound 1; then compounds 2 and 3 (each within the scatter of the next).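

In this assay, among these compounds, 1H-indol-7-yl in place of 4-methoxyphenyl on a saturated chain carbon bound to an aromatic nitrogen gives a number 0.70 log units higher from compound 1 to compound 3 (beyond the scatter), the first step here that isolates a single change. It shows that this position alone can move the number beyond the scatter while the rest of the compound stays the same. No measured evidence accounts for the size of this step. Still open, from the compounds shown here alone, is what a plain phenyl or a 1-methyl-1H-indol-7-yl group would give at this place, and whether the same step would hold with a different amide on the shared core.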